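The source may report more compounds than this note shows. Statements on the series, on what has been measured and on what is new or still open speak of the compounds shown alone.

Among the compounds with values here, in an ADME assay on microsomes from liver (Mus musculus) for metabolic stability, using NADPH, with a stated time of 10 min (on this read-out lower numbers stand for a less stable compound and higher numbers for a more stable compound), compound 2 `CN(C[C@H]1Cc2ncccc2CN1)[C@H]1CCCc2cccnc21` gives the highest of the three numbers so far (53%). Compound 1 `NCCCCN(C[C@@H]1Cc2cccnc2CN1)[C@H]1CCCc2cccnc21` stands lower (25%), and compound 3 `CN(C[C@@H]1Cc2ncccc2CN1)[C@H]1CCCc2cccnc21` lies lowest (0%). Compound 4 `NC(=O)NCCCCN(C[C@H]1Cc2ncccc2CN1)[C@H]1CCCc2cccnc21` departs from compound 2 through one change, 3-ureidopropyl in place of hydrogen on a saturated chain carbon bound to an amine nitrogen.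

Within the data shown here, no measured step tests such a change directly. The only one is large (a number 53 percentage points lower from compound 2 to compound 3 (beyond the scatter)) and concerns configuration alone the fact that compounds 2 and 3 differ only in the configuration as drawn so it shows how far the numbers can move but gives no size for this change. The nearest guide is compound 1, whose value of 25% lies well under that of compound 2, and this suggests a fall rather than a rise. The expected change in this assay is a drop beyond the scatter, with wide uncertainty (a number 23 percentage points lower from compound 2 to compound 4 (beyond the scatter)). For compound 4 the estimate is 30% (expected range 8% to 58%).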

Compound 4, percent of the compound remaining: 32%
For compound 4 the middle estimate is 2 percentage points below the measured one, and the stated range covers the measured number.
By their numbers in this assay, from the lowest: compound 3; then compounds 1 and 4 (each within the scatter of the next); then compound 2.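

In this assay, 3-ureidopropyl in place of hydrogen on a saturated chain carbon bound to an amine nitrogen gives a number 21 percentage points lower from compound 2 to compound 4 (beyond the scatter), the first measured size for a change at this place. The chain costs stability here, yet the step is modest beside the large one seen for configuration alone, a number 53 percentage points lower from compound 2 to compound 3 (beyond the scatter). Nothing at hand accounts for the fall in compound 4.

The compounds shown leave open whether the fall follows the length of the chain or the ureido group at its end: a plain butyl chain, or an amine or a carboxylic acid in place of the ureido group on the core of compound 2, would separate the two. From the compounds shown here alone, how a shorter chain carrying the same ureido group would read also remains open.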